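From 3,4-difluorophenyl to 3,5-difluorophenyl: working notes

This account rests on a few compounds, and the source may have more. Where it says the series, first, only, none or still open, it means among the compounds named here.

Measured in an ADME assay on HEK293 cells (Homo sapiens) for cytotoxicity, with a stated time of 72 h (on this read-out higher numbers stand for an effect only at larger amounts of compound and lower numbers for an effect already at smaller amounts), so far:
Compound 1 `C=C[C@@](C)(/C=C/c1ccc(Nc2ccccc2)cc1)CCC=C(C)C` gives > 36600 nM (a limit)
Compound 2 `C=C[C@@](C)(/C=C/c1ccc(Nc2ccc(F)cc2)cc1)CCC=C(C)C` gives > 36600 nM (a limit)
Compound 3 `C=C[C@@](C)(/C=C/c1ccc(Nc2ccc(F)c(F)c2)cc1)CCC=C(C)C` gives > 36600 nM (a limit)

Compound 3 gives > 36600 nM as a limit of the assay, not as a number. Within the data shown here, the whole set is described by the limit of > 36600 nM in this assay, at which 3 of the 3 values shown sit, and so offers no order among the compounds.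

Compound 4 `C=C[C@@](C)(/C=C/c1ccc(Nc2cc(F)cc(F)c2)cc1)CCC=C(C)C` is still unmeasured and differs from compound 3 as follows (3,5-difluorophenyl in place of 3,4-difluorophenyl on a nitrogen on an aromatic ring). The measured steps that bear on this change are the fluoro replacements (a step that the two limits leave unreadable from compound 1 to compound 2) and (a step that the two limits leave unreadable from compound 2 to compound 3), together with the change to 3,4-difluorophenyl (a step that the two limits leave unreadable from compound 1 to compound 3). None of them has a readable size. No step beyond the scatter is therefore expected in this assay and no direction is assigned. The expected step is (a number no higher from compound 3 to compound 4 (the limit leaves the size open)). The estimate for compound 4 is 36600 nM with an expected range from 18000 nM to 73000 nM and a report as a limit is the likely outcome.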

Compound 4, half-maximal effective concentration: > 36600 nM
Compound 4 was reported as a limit (the forecaster's own chance of this, stated with the estimate: 90%); the middle value lies on the limit itself.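

In this assay no new step can be read: compound 4 set against compound 1, compound 2 and compound 3 gives only pairs of limits. What stays open is whether these fluoro replacements shift the read-out at all, as the set shows no order: the limit of > 36600 nM in this assay, at which 4 of the 4 values shown sit.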